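A few compounds are considered here, and "the series" means these few. Any claim that something is new, unique, unknown or untested is made for them only; others in the source may bear on it.

Measured in the assay below (an ADME assay on microsomes from liver (Rattus norvegicus) for metabolic stability, with a stated time of 10 min, tested at 0.5 uM; a lower number here means that less of the compound is left, a higher number that more of the compound is left)
- compound 1 `CC(C)Cc1ccc(-c2cn(C)c3cc(C(=O)NS(C)(=O)=O)ccc23)cc1` gives 94%
- compound 2 `CC(C)COc1ncc(-c2nn(C)c3cc(C(=O)NS(C)(=O)=O)ccc23)cc1Cl` gives 100%
- compound 3 `Cn1cc(-c2ccc(C(F)F)cc2)c2cc(F)c(C(=O)NS(=O)(=O)C3CC3)cc21` gives 82%

Compound 1 (94%) stands within the scatter of compound 2 and beyond the scatter above compound 3. The account now turns to compound 4 `Cn1cc(-c2ccc(C(F)(F)F)cc2)c2ccc(C(=O)NS(C)(=O)=O)cc21`, which has not yet been measured. It differs from compound 1 in one place only: trifluoromethyl in place of isobutyl on an aromatic carbon. Trifluoromethyl replaces isobutyl on an aromatic carbon, para to a large group, and the core of compound 1 stays as it is.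

Going by the values given here, no two measured compounds differ in one place alone, so no measured step can guide the expectation. Among the compounds with values here, the only guide is that compound 3 (82%) , the lowest of the three, still keeps most of its material. In this assay no step beyond the scatter is therefore expected, and no clear direction can be given. The expected change is a number 1 percentage points lower from compound 1 to compound 4 (within the scatter) and it should stay within the scatter. For compound 4 the estimated value is 93%, with an expected range from 80% to 100% in this read-out.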

Compound 4, percent of the compound remaining: 74%
Compound 4: the middle estimate sits 19 percentage points above what was measured; measured number below the stated range.
By their numbers in this assay, from the lowest: compounds 4 and 3 (each within the scatter of the next); then compounds 1 and 2 (each within the scatter of the next).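

Trifluoromethyl in place of isobutyl, on an aromatic carbon para to a large group, brings a number 20 percentage points lower from compound 1 to compound 4 (beyond the scatter) in this assay. Going by these compounds alone, this is the first comparison here between compounds that differ in one place alone, and it shows that the number in this read-out responds to the group at this position while the core of compound 1 stays as it is. No evidence at hand bears on what lies behind this step.

A single step leaves open whether the lower number goes with the loss of isobutyl or with the arrival of trifluoromethyl. On these data alone, how an ethyl chain or a methoxy group on the same aromatic carbon would stand in this assay also remains open, as does whether the same exchange would give a similar step on another core.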